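The source may report more compounds than this note shows. Statements on the series, on what has been measured and on what is new or still open speak of the compounds shown alone.

In a functional assay for inhibition, with Homo sapiens as the target (a lower number here means a stronger inhibitor, a higher number a weaker inhibitor), compound 1 (`CC(COc1ccc2c(c1)c(SC(C)(C)C)c(CC(C)(C)C(=O)O)n2Cc1ccc(Cl)cc1)c1ccccn1`) gives 4 nM, and compound 2 (`CC(C)(C)Sc1c(CC(C)(C)C(=O)O)n(Cc2ccc(Cl)cc2)c2ccc(OCc3cnccn3)cc12`) gives 4 nM, so compound 2 stands level with compound 1 at the digits shown. Compound 3 (`CC(C)(C)Sc1c(CC(C)(C)C(=O)O)n(Cc2ccc(Cl)cc2)c2ccc(OCc3cccs3)cc12`) carries thiophen-2-yl in place of pyrazin-2-yl on a saturated chain carbon bound to an oxygen on an aromatic ring. Among the measured compounds shown here, one measured step bears on this place: no change at the digits printed from compound 1 to compound 2 (within the scatter). That exchange of 1-(pyridin-2-yl)ethyl for pyrazin-2-yl stayed within the scatter. For the measured compounds named here, no measured compound carries thiophen-2-yl, so this single step is thin support. Even so, no change beyond the scatter is expected in this assay, and no direction is favoured. The estimated step is no change at the digits printed from compound 2 to compound 3 (within the scatter). For compound 3 the expected value is 4 nM, with an estimated range of 2 nM to 9 nM.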

Compound 3, half-maximal inhibitory concentration: 4 nM
For compound 3 middle estimate and measured number coincide at the digits printed, and the stated range covers the measured number.
By their numbers in this assay, from the lowest: compounds 1, 2 and 3 (each within the scatter of the next).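

Putting thiophen-2-yl in place of pyrazin-2-yl on a saturated chain carbon bound to an oxygen on an aromatic ring gives no change at the digits printed from compound 2 to compound 3 (within the scatter) in this assay, and the comparison with the 1-(pyridin-2-yl)ethyl group gives no change at the digits printed from compound 1 to compound 3 (within the scatter) as well. The place therefore now holds a five-membered aromatic ring with a sulfur atom as well as six-membered aromatic rings with nitrogen, and across these three compounds neither exchange moves the read-out beyond the scatter. No evidence is available on what lies behind this sameness.

Going by these compounds, all three groups carry an aromatic ring, so it remains open whether an amine, a carboxylic acid or a plain longer alkyl chain at this place would keep the value in this assay. On these data alone, whether substituents on the thiophene ring would do so is also open.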